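Working notes: two cytotoxicity limits and a chain extension

The source may report more compounds than this note shows. Statements on the series, on what has been measured and on what is new or still open speak of the compounds shown alone.

Measured so far:
- compound 1, `CS(=O)(=O)CCCn1c(Cn2nc(S(C)(=O)=O)c3ccccc32)nc2cc(Cl)ccc21`: > 100000 nM
- compound 2, `CS(=O)(=O)c1nn(Cc2nc3cc(Cl)ccc3n2CCO)c2cnccc12`: > 100000 nM

Both readings in an ADME assay on HEp-2 cells (Homo sapiens) for cytotoxicity, with a stated time of 4 days (on this read-out lower numbers stand for higher toxicity in this test and higher numbers for lower toxicity in this test), are limits of the assay rather than numbers. Compound 1 sits at the limit > 100000 nM. Among the measured compounds shown here, compound 2 likewise sits at the limit > 100000 nM, so its standing is known only as a limit, and the one further value shown is also a limit. The two structures differ in more than one place, so no single step can be read between them; all that the pair shows is that both reach the same limit, (the limit of > 100000 nM in this assay, at which 2 of the 2 values shown sit).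

Compound 3, `CS(=O)(=O)c1nn(Cc2nc3cc(Cl)ccc3n2CCOCCO)c2cnccc12`, is the next member to be measured. It differs from compound 2 in one place: 2-hydroxyethyl in place of hydrogen on an oxygen on a saturated carbon. No measured step of this kind exists in the series, so no direction can be drawn from the shown data. The expectation for the step from compound 2 to compound 3 is therefore none beyond the scatter, a number no higher from compound 2 to compound 3 (the limit leaves the size open). Compound 3 is estimated to come out at 100000 nM, within the range 50000 nM to 200000 nM, most likely as a limit again.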

Compound 3, half-maximal cytotoxic concentration: > 100000 nM
Compound 3 ended at the assay's limit; the forecaster's own chance of this, stated with the estimate: 85%; the middle value sits exactly at the limit.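

In this assay compound 3 gives > 100000 nM, which is a limit of the assay. Compound 2 also stands at a limit, so no step can be read from compound 2 to compound 3. The compounds shown leave open how the three compounds would rank in this read-out, because all of them share one limit: the limit of > 100000 nM in this assay, at which 3 of the 3 values shown sit.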